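Extending the Hydroxyalkyl Sulfonamide Chain by One Carbon

This account rests on a few compounds, and the source may have more. Where it says the series, first, only, none or still open, it means among the compounds named here.

Of the compounds shown here, three sharing one core have been measured in a functional assay on K562 cells (Homo sapiens) for antiproliferative activity, read by CCK-8 assay, with a stated time of 72 h; a lower number here means a stronger inhibitor of growth, a higher number a weaker inhibitor of growth. Compound 1, `CC[C@@H]1C(=O)N(C)c2cnc(Nc3ccc(S(=O)(=O)NCCO)cc3)nc2N1C1CCCC1`, gives 546 nM in this assay, the lowest of the three numbers. Compound 2, `CCC1C(=O)N(C)c2cnc(Nc3ccc(S(=O)(=O)NC)cc3)nc2N1c1ccn(C)n1`, gives 2890 nM in this assay, a number that stands beyond the scatter above that of compound 1. Compound 3, `CCC1C(=O)N(C)c2cnc(-n3ccc4cc(F)ccc43)nc2N1c1ccn(C)n1`, gives 6070 nM in this assay, the highest of the three and likewise beyond the scatter from compound 1. Compounds 2 and 3 differ from compound 1 in more than one place, so their values say only where each stands, not what any single change contributes.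

Compound 4, `CC[C@@H]1C(=O)N(C)c2cnc(Nc3ccc(S(=O)(=O)NCCCO)cc3)nc2N1C1CCCC1`, has not yet been measured. It differs from compound 1 in a single way: hydroxymethyl in place of hydroxy on a saturated chain carbon, two bonds along the chain from a sulfonamide nitrogen. Read one bond further out, this is 2-hydroxyethyl becoming 3-hydroxypropyl on the sulfonamide nitrogen.

Among the measured compounds shown here, no measured pair shows the effect of such a chain extension here. With the hydroxy group retained and only one chain carbon added, the step of a 1.1-fold higher number from compound 1 to compound 4 (0.06 log units; within the scatter) is expected to stay within the usual scatter, in either direction. Compound 4 is therefore estimated at 620 nM in this assay, in the range 250 nM to 1500 nM.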

Compound 4, concentration for 50% growth inhibition: 331 nM
Beside the measured number, compound 4's estimate is 1.9-fold (0.27 log units) above it; the measured number falls inside the stated range.
By their numbers in this assay, from the lowest: compounds 4 and 1 (each within the scatter of the next); then compound 2; then compound 3.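

Among the compounds shown here, this is the first single-place step: in this assay, 2-hydroxyethyl becoming 3-hydroxypropyl on the sulfonamide nitrogen gives a 1.6-fold lower number from compound 1 to compound 4 (0.22 log units; within the scatter) and so leaves the number within the scatter. At this place, on a saturated chain carbon, two bonds along the chain from a sulfonamide nitrogen, the chain can therefore take hydroxymethyl in place of hydroxy without a change that can be read, something compounds 2 and 3 could not show since they differ from compound 1 in more than one place. Nothing measured here gives a reason for this result.

Still open, on these data alone, is how far the chain can go, and whether the hydroxy group matters at all: a longer chain such as 4-hydroxybutyl, a plain propyl chain, or a chain ending in an amine or a carboxylic acid would each test this. Also open, as far as these compounds go, is whether the same extension would read alike with the other groups that compound 2 carries on the shared core.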